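Pyrrolidin-3-yl replacing the 4-nitrophenyl of compound 2

This account rests on a few compounds, and the source may have more. Where it says the series, first, only, none or still open, it means among the compounds named here.

Measured in a functional assay on DU-145 cells (Homo sapiens) for inhibition, read by trypan blue exclusion, with a stated time of 96 h; a higher number here means a weaker inhibitor of growth, a lower number a stronger inhibitor of growth:
- compound 1 `O=C(/C(=C\c1ccc(O)c([N+](=O)[O-])c1)SCc1ccc(Br)cc1)c1ccc(O)cc1O` gives > 100000 nM (a limit)
- compound 2 `O=C(/C(=C\c1ccc(O)c([N+](=O)[O-])c1)SCc1ccc(Br)cc1)c1ccc([N+](=O)[O-])cc1` gives 10000 nM

Going by the values given here, compound 2 carries the only true number, the value of compound 1 being a limit. Compound 3 `O=C(/C(=C\c1ccc(O)c([N+](=O)[O-])c1)SCc1ccc(Br)cc1)C1CCNC1` differs from compound 2 in one place: pyrrolidin-3-yl in place of 4-nitrophenyl on a carbonyl carbon. Among the compounds with values here, one measured step bears on this place: an at least 10-fold lower number from compound 1 to compound 2 (1.00 log units; beyond the scatter) with the 4-nitrophenyl entering. On that step, a moderate rise in the number is expected in this assay once this group leaves compound 2 at 10000 nM and its present level. The expected size is a 2.0-fold higher number from compound 2 to compound 3 (0.30 log units; within the scatter) as an estimate. For compound 3 the expected value is 20000 nM with an estimated range from 5000 nM to 100000 nM in this series.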

Compound 3, concentration for 50% growth inhibition: > 100000 nM
Compound 3: only a limit was reported; the forecaster's own chance of this, stated with the estimate: 30%; at least 5.0-fold (0.69 log units) between middle value and limit.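

In this assay, pyrrolidin-3-yl on the carbonyl carbon gives an at least 10-fold higher number from compound 2 to compound 3 (1.00 log units; beyond the scatter) against the 4-nitrophenyl, so a non-aromatic ring fares no better here than the 2,4-dihydroxyphenyl of compound 1. Among the three groups shown, only the 4-nitrophenyl gives a true number rather than a limit. On these data alone, the step between compound 1 and compound 3 cannot be read, and the full size of the loss stays unknown: the limit of > 100000 nM in this assay, at which 2 of the 3 values shown sit.

Open, as far as these compounds go, is whether the nitro group or the aromatic ring carries the gain, which plain phenyl or 4-aminophenyl would separate. Whether an open-chain amine behaves like pyrrolidin-3-yl also remains unsettled.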